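The source may report more compounds than this note shows. Statements on the series, on what has been measured and on what is new or still open speak of the compounds shown alone.

Within the data shown here, in a functional assay on MT4 cells (Homo sapiens) for cytotoxicity, read by MTT assay (a lower number here means that less compound is tolerated, a higher number that more compound is tolerated), compound 1 (`Cc1c(O)nc(SCc2ccc(O)cc2)nc1Cc1c(Cl)cccc1Cl`) gives 41000 nM, the only exact number available. Compound 2 (`Cc1c(O)nc(S(=O)(=O)Cc2ccc(Br)cc2)nc1Cc1c(Cl)cccc1Cl`) gives > 50000 nM, which is a limit of the assay and not a number. Compound 3 (`CCOc1ccc(CSc2nc(O)c(C)c(Cc3c(Cl)cccc3Cl)n2)cc1`) departs from compound 1 in one place: ethyl in place of hydrogen on an oxygen on an aromatic ring, with ethyl in place of hydrogen on an oxygen on an aromatic ring, so that 4-hydroxyphenyl becomes 4-ethoxyphenyl. Among the measured compounds shown here, no measured step covers this change. No shift beyond the scatter is expected in this assay, with a slight lean towards less compound tolerated. The estimated change is a 1.4-fold lower number from compound 1 to compound 3 (0.14 log units; within the scatter). Compound 3 is expected at 30000 nM, within a range of 9000 nM to 70000 nM.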

Compound 3, half-maximal cytotoxic concentration: > 58000 nM
Compound 3 ended at the assay's limit (the forecaster's own chance of this, stated with the estimate: 35%); middle value at least 1.9-fold (0.28 log units) from the limit.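

Among these compounds, the step at this oxygen, with ethyl in place of hydrogen, is the first one available at this position: in this assay it gives an at least 1.4-fold higher number from compound 1 to compound 3 (0.15 log units; that floor lies within the scatter). Turning 4-hydroxyphenyl into 4-ethoxyphenyl therefore brings no drop in the number beyond the scatter. The true size of the step cannot be read, because compound 3 stands at a limit of the assay and not at a number: the limit of > 58000 nM in this assay, at which 1 of the 3 values shown sits.

From the compounds shown here alone, whether a longer chain on this oxygen, or an amine in its place, would bring the number down remains open.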